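Piperidine carboxamide to acetyl-ethylamino pyrrolidine: one step

The compounds below may be only part of what the source reports. "The series", "measured", "known", "first", "only" and "open" are said of these compounds alone.

Within the data shown here, compound 1 `NC(=O)C1CCN(c2nc(-c3ccccn3)nc3c2CN(Cc2ccccc2)CC3)CC1` gives 34.4% in an assay on A549 cells with Cystic fibrosis transmembrane conductance regulator variant F508del (Homo sapiens) as the target, read by fluorescence, with a stated time of 25 min (on this read-out higher numbers stand for larger maximal responses and lower numbers for smaller maximal responses), the only numeric value in this set. Compound 2 `COc1ccc(CN2CCc3nc(-c4ccccn4)nc(N4CCC(C(N)=O)CC4)c3C2)cc1` carries a methoxy on its benzyl group where compound 1 has none, and in this assay compound 2 is reported as "not active" (no number reported) with no number attached, so compound 2 stands at the bottom of what the set shows, without a figure to anchor a step. Compound 3 `CCN(C(C)=O)C1CCN(c2nc(-c3ccccn3)nc3c2CN(Cc2ccc(OC)cc2)CC3)C1` keeps the methoxy-bearing benzyl of compound 2 and differs from it by 3-(acetyl(ethyl)amino)pyrrolidin-1-yl in place of 4-carbamoylpiperidin-1-yl on an aromatic carbon. Among the measured compounds shown here, no measured pair in the set follows this change, so its size and direction in this assay cannot be read from data; the one comparison available, compound 1 against compound 2, concerns the other end of the shared core and sets a number against a blank. With compound 2 inactive and nothing to guide the change, the expectation for compound 3 is a small maximal response, quite possibly reported again as inactive. Compound 3 is estimated at 15%, with an expected range from 0% to 40%.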

Compound 3, largest response reached (Emax), in percent of the reference or control that the assay uses: "not active" (no number reported)
No number was reported for compound 3, and the estimate cannot be compared.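

Between compound 2 and compound 3 no step can be read: in this assay compound 2 gives "not active" (no number reported) and compound 3 gives "not active" (no number reported) with no number on either side. No supporting data bear on this result. The compounds shown leave open how 3-(acetyl(ethyl)amino)pyrrolidin-1-yl compares with 4-carbamoylpiperidin-1-yl in maximal response.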